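This account rests on a few compounds, and the source may have more. Where it says the series, first, only, none or still open, it means among the compounds named here.

Compound 1 `c1ccc(-c2cccc3c2CCC3c2ncc[nH]2)nc1` carries a pyridin-2-yl group on its core. In a functional assay on CHO cells for agonist activity at Alpha-1B adrenergic receptor (Homo sapiens), read by FLIPR and calcium flux (on this read-out lower numbers stand for an effect already at smaller amounts and higher numbers for an effect only at larger amounts of compound), compound 1 gives only a limit, > 10000 nM, and no number. Compound 2 `CCCS(=O)(=O)Nc1cccc2c1CCC2c1ncc[nH]1` likewise reaches only a limit in this assay, > 10000 nM. Compound 3 `c1ccc2c(c1)CCC2c1ncc[nH]1`, the bare core, also stays at a limit in this assay, > 10000 nM. The three measured steps therefore say nothing about size: a step that the two limits leave unreadable from compound 1 to compound 2, a step that the two limits leave unreadable from compound 1 to compound 3 and a step that the two limits leave unreadable from compound 2 to compound 3 are all unreadable, because of the limit of > 10000 nM in this assay, at which 3 of the 3 values shown sit. Compound 4 `c1cc(-c2nccs2)c2c(c1)C(c1ncc[nH]1)CC2` is the unmeasured partner of compound 1; it differs by 1,3-thiazol-2-yl in place of pyridin-2-yl on an aromatic carbon. No measured step bears directly on this change, and the only pattern shown is that every substituent tried on that aromatic carbon, as well as none at all, leaves the compound at the limit. The step from compound 1 to compound 4 is thus expected to be a step that the limit leaves unreadable from compound 1 to compound 4, that is, nothing readable. Compound 4 is expected to give about 15000 nM, within 4000 nM to 60000 nM, most probably reported again only as a limit.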

Compound 4, half-maximal effective concentration: > 10000 nM
Compound 4 ended at the assay's limit (the forecaster's own chance of this, stated with the estimate: 80%); the middle value does not contradict the limit.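

Compound 4 joins compounds 1, 2 and 3 at a limit, so none of the steps among these compounds can be read: the limit of > 10000 nM in this assay, at which 4 of the 4 values shown sit. The compounds shown leave open whether any group on that aromatic carbon gives a readable value in this assay at all.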